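Chain extension at the ether oxygen: compound 1 to compound 3

A few compounds are considered here, and "the series" means these few. Any claim that something is new, unique, unknown or untested is made for them only; others in the source may bear on it.

Two compounds have numbers in a functional assay on HeLa cells (Homo sapiens) for cytotoxicity; on this read-out lower numbers stand for stronger inhibition and higher numbers for weaker inhibition. Compound 1 `CCOC1=CC(=O)c2ccccc2C1=O` gives 23800 nM in this assay; compound 2 `COc1ccc2c(c1)C(=O)C=CC2=O` gives 22700 nM, and the two numbers lie within the scatter of each other, so compound 1 stands apart from nothing in the set. Compound 3 `CCCOC1=CC(=O)c2ccccc2C1=O` is not yet measured; it differs from compound 1 by methyl in place of hydrogen on a saturated chain carbon, two bonds along the chain from an oxygen on an unsaturated carbon. Among the measured compounds shown here, no step between measured compounds covers this change, so nothing here calibrates it. The expected step of a 1.3-fold lower number from compound 1 to compound 3 (0.12 log units; within the scatter) is small, not beyond the scatter. Compound 3 is expected at 18000 nM, with a range from 8000 nM to 40000 nM.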

Compound 3, half-maximal inhibitory concentration: 51600 nM
Compound 3: middle estimate off by 2.9-fold (0.46 log units), on the low side, outside the stated range (above it).
By their numbers in this assay, from the lowest: compounds 2 and 1 (each within the scatter of the next); then compound 3.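

Ethoxy to propoxy is the first change in this series to register beyond the scatter in this assay, with a 2.2-fold higher number from compound 1 to compound 3 (0.34 log units; beyond the scatter), a modest step toward weaker inhibition. The ether chain on the core of compound 1 is therefore not a silent position, even for a single added methyl. Nothing available accounts for this step.

A single step fixes no trend along the chain. As far as these compounds go, whether a butoxy group continues this direction, or an amine-bearing chain departs from it, remains open.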